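Solubility at low pH: pyridin-2-yl in place of methoxymethyl

The source may hold more compounds than are shown below. What is called first, only, known or untested is meant among the compounds shown, and "the series" means these compounds.

Three compounds have been measured in a physicochemical assay for solubility, with a stated time of 24 h, at pH 3; on this read-out lower numbers stand for lower solubility and higher numbers for higher solubility:
compound 1 `Cc1cc(-c2cnc(N3CCN(C)CC3)nc2-c2ccc(C)s2)on1`, 11000 nM
compound 2 `COCCNc1ncc(-c2cc(C)no2)c(C2CCN(C(C)=O)CC2)n1`, 233000 nM
compound 3 `Cc1cc(-c2cnc(NCc3cccnc3)nc2-c2ccc(C)s2)on1`, 1000 nM

Compound 2 stands highest of the three, beyond the scatter above compound 1 and further still above compound 3. Compound 4 `CC(=O)N1CCC(c2nc(NCc3ccccn3)ncc2-c2cc(C)no2)CC1` differs from compound 2 by pyridin-2-yl in place of methoxymethyl on a saturated chain carbon bound to a nitrogen on an aromatic ring.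

Among the measured compounds shown here, only one measured step bears on this: an 11-fold lower number from compound 1 to compound 3 (1.04 log units; beyond the scatter), which also put a pyridinylmethylamino group onto the core of compound 1, though from a different starting group. Nothing covers the present exchange directly. A decrease of modest size is therefore expected in this assay, a 3.3-fold lower number from compound 2 to compound 4 (0.52 log units; beyond the scatter). Compound 4 is estimated at 70000 nM, with a range from 20000 nM to 200000 nM.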

Compound 4, solubility: 221000 nM
The estimate for compound 4 lay 3.2-fold (0.50 log units) below the measured number; measured number outside the range, above it.
By their numbers in this assay, from the lowest: compound 3; then compound 1; then compounds 4 and 2 (each within the scatter of the next).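

In this assay the step of a 1.1-fold lower number from compound 2 to compound 4 (0.02 log units; within the scatter) lies within the scatter, so at this saturated chain carbon bound to a nitrogen on an aromatic ring, pyridin-2-yl and methoxymethyl cannot be told apart. The large step of an 11-fold lower number from compound 1 to compound 3 (1.04 log units; beyond the scatter) therefore does not carry over to this exchange, which has a different starting group on a different core. Nothing measured here accounts for this result.

The compounds shown leave open whether a carboxylic acid or an open-chain amine at this place would also read alike. They also leave open how the same exchange would read on the core of compound 1.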